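A second fluoro where hydroxy and methyl stood

The source may hold more compounds than are shown below. What is called first, only, known or untested is meant among the compounds shown, and "the series" means these compounds.

Of the compounds shown here, three sharing one core have been measured in a functional assay on MCF7 cells (Homo sapiens) for cytotoxicity; a higher number here means a weaker inhibitor, a lower number a stronger inhibitor. Compound 1 `C=C/C=C\[C@H](C)[C@H](OC(N)=O)[C@@H](C)[C@H](O)[C@@H](C)C/C(C)=C\[C@H](C)[C@@H](O)[C@@H](C)/C=C\CCc1ccc(C)c(F)c1` gives 4000 nM, compound 2 `C=C/C=C\[C@H](C)[C@H](OC(N)=O)[C@@H](C)[C@H](O)[C@@H](C)C/C(C)=C\[C@H](C)[C@@H](O)[C@@H](C)/C=C\CCc1cccc(F)c1` gives 500 nM, and compound 3 `C=C/C=C\[C@H](C)[C@H](OC(N)=O)[C@@H](C)[C@H](O)[C@@H](C)C/C(C)=C\[C@H](C)[C@@H](O)[C@@H](C)/C=C\CCc1ccc(C)c(O)c1` gives 4000 nM. Compound 3 therefore stands level with compound 1, and these two share the highest number of the three. The unmeasured compound 4 `C=C/C=C\[C@H](C)[C@H](OC(N)=O)[C@@H](C)[C@H](O)[C@@H](C)C/C(C)=C\[C@H](C)[C@@H](O)[C@@H](C)/C=C\CCc1cc(F)cc(F)c1` carries 3,5-difluorophenyl in place of the 3-hydroxy-4-methylphenyl of compound 3, on a saturated chain carbon, two bonds along the chain from a double-bonded chain carbon: 3,5-difluorophenyl in place of 3-hydroxy-4-methylphenyl on a saturated chain carbon, two bonds along the chain from a double-bonded chain carbon.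

All three measured steps bear on this change. Hydroxy in place of fluoro on an aromatic carbon gave no change at the digits printed from compound 1 to compound 3 (within the scatter). Hydrogen in place of methyl on an aromatic carbon gave an 8.0-fold lower number from compound 1 to compound 2 (0.90 log units; beyond the scatter), and 3-hydroxy-4-methylphenyl in place of 3-fluorophenyl gave an 8.0-fold higher number from compound 2 to compound 3 (0.90 log units; beyond the scatter). Compound 4 has no methyl on its ring, as in compound 2 at 500 nM, so it is expected to fall near that compound. Going by the values given here, no measured compound shows what a second fluoro does, which keeps the range wide. A modest step toward a lower number is expected, a 6.7-fold lower number from compound 3 to compound 4 (0.82 log units; beyond the scatter). Compound 4 is estimated at 600 nM, with an expected range of 150 nM to 2500 nM.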

Compound 4, half-maximal inhibitory concentration: 2000 nM
Compound 4: middle estimate off by 3.3-fold (0.52 log units), on the low side; low and high end bracket the measured number.
By their numbers in this assay, from the lowest: compound 2; then compounds 4, 1 and 3 (each within the scatter of the next).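

In this assay, losing the ring methyl proves not to be enough to reach the lower number of compound 2: fluoro in place of hydrogen on an aromatic carbon gives a clear step upward (a 4.0-fold higher number from compound 2 to compound 4 (0.60 log units; beyond the scatter)), so a ring without methyl can still sit with the higher numbers. 3,5-Difluorophenyl in place of 3-hydroxy-4-methylphenyl (a 2.0-fold lower number from compound 3 to compound 4 (0.30 log units; within the scatter)) and in place of 3-fluoro-4-methylphenyl (a 2.0-fold lower number from compound 1 to compound 4 (0.30 log units; within the scatter)) leaves compounds 1, 3 and 4 indistinguishable from one another, and compound 2, with its 3-fluorophenyl, is the only one of the four set apart. Nothing available explains the effect of the second fluoro on this ring.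

On these data alone, it remains open whether the lower number belongs to 3-fluorophenyl in particular, since plain phenyl, 3-chlorophenyl and 3-methoxyphenyl would each test this on the same chain carbon. Also open, as far as these compounds go, is whether a longer chain between the double-bonded carbon and the ring would shift the number for the 3-fluorophenyl and 3,5-difluorophenyl rings alike.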